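Acylating the ring amine of compound 1

The source may report more compounds than this note shows. Statements on the series, on what has been measured and on what is new or still open speak of the compounds shown alone.

For the measured compounds named here, in a functional assay on NCI-H1975 cells (Homo sapiens) for antiproliferative activity (on this read-out lower numbers stand for stronger inhibition and higher numbers for weaker inhibition), compound 1 `Cc1c2c(n3c1CCNC[C@@H](C)[C@H](C)Nc1cc-3ccc1C(N)=O)CC(C)(C)CC2=O` gives 27 nM as the lower of the two numbers so far. Going by the values given here, compound 2 `Cc1c2c(n3c1CCCN(C(=O)CN)[C@@H](C)[C@H](C)Nc1cc-3ccc1C(N)=O)CC(C)(C)CC2=O` gives 380 nM and is the one measured compound with a carbonyl on a ring nitrogen. Compound 3 `CC[C@H](N)C(=O)N1CCc2c(C)c3c(n2-c2ccc(C(N)=O)c(c2)N[C@@H](C)[C@H](C)C1)CC(C)(C)CC3=O` carries (1-aminopropyl)carbonyl in place of hydrogen on an amine nitrogen in a ring. Among the compounds with values here, no measured step isolates this change. Within the data shown here, with compound 2 at 380 nM as the only guide, weaker inhibition is expected. In this assay the expected 6.3-fold higher number from compound 1 to compound 3 (0.80 log units; beyond the scatter) lies beyond the scatter, toward higher numbers. For compound 3 the estimate is 170 nM with 40 nM to 700 nM as the expected range.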

Compound 3, half-maximal inhibitory concentration: 41 nM
Estimate against measurement, compound 3: 4.1-fold (0.62 log units) above, and the stated range covers the measured number.
By their numbers in this assay, from the lowest: compounds 1 and 3 (each within the scatter of the next); then compound 2.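

In this assay, (1-aminopropyl)carbonyl in place of hydrogen on this amine nitrogen in a ring gives a 1.5-fold higher number from compound 1 to compound 3 (0.18 log units; within the scatter), so this position carries the group without a change beyond the scatter. For the compounds shown here, this is the first single-place reading at this nitrogen, since compound 2 differs from compound 1 in more than one place. No measurement on hand accounts for the result.

Open, as far as these compounds go, is whether the opposite configuration at the new stereocentre, a longer chain, or a carboxylic acid in place of the amine would leave the number within the scatter.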